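This account rests on a few compounds, and the source may have more. Where it says the series, first, only, none or still open, it means among the compounds named here.

For the measured compounds named here, compound 2 `CCC(C)(C)Cc1c[nH]c(CCc2ccc(-n3ccnn3)cc2)n1` stands at 641 nM in a functional assay on HEK293 cells for agonist activity at Bombesin receptor subtype-3 (Homo sapiens), read by luminescence and calcium flux, with a stated time of 10 min (a higher number here means that more compound is needed for the effect, a lower number that less compound is needed), and only one other compound has been measured. Compound 1 `CCC(C)(C)Cc1c[nH]c(CCc2ccc(-c3csnn3)cc2)n1` gives 538 nM in this assay, so the step of a 1.2-fold higher number from compound 1 to compound 2 (0.08 log units; within the scatter) sits within the scatter of repeated measurements. Compound 3 `CCC(C)(C)Cc1c[nH]c(CCc2ccc(-n3cncn3)cc2)n1` differs from compound 2 by 1H-1,2,4-triazol-1-yl in place of 1H-1,2,3-triazol-1-yl on an aromatic carbon. Going by the values given here, the single measured step, an exchange of one ring group for another on the same aromatic carbon, barely moved the number, so little movement is expected here, with the estimated step of a 1.0-fold lower number from compound 2 to compound 3 (0.01 log units; within the scatter). For compound 3 the expected value is 620 nM, with a range from 300 nM to 1300 nM.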

Compound 3, half-maximal effective concentration: 570 nM
Compound 3: the middle estimate sits 1.1-fold (0.04 log units) above what was measured; measured number inside the range.
By their numbers in this assay, from the lowest: compounds 1, 3 and 2 (each within the scatter of the next).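

Rearranging the ring nitrogens of the triazole, with the same atoms joined differently, makes no difference that can be told from scatter (a 1.1-fold lower number from compound 2 to compound 3 (0.05 log units; within the scatter)). Replacing the 1,2,3-thiadiazol-4-yl group with 1H-1,2,4-triazol-1-yl also gives a step within the scatter (a 1.1-fold higher number from compound 1 to compound 3 (0.03 log units; within the scatter)), so this position tolerates all three five-membered aromatic rings equally in this measurement. No measured evidence is available to explain this.

Going by these compounds, whether an amine or a carboxylic acid on this aromatic carbon would leave the number unchanged remains open. So does whether changes elsewhere on the shared core would move it.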